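The source may hold more compounds than are shown below. What is called first, only, known or untested is meant among the compounds shown, and "the series" means these compounds.

In an ADME assay on CCRF-CEM cells (Homo sapiens) for antiproliferative activity, with a stated time of 48 h (on this read-out lower numbers stand for stronger inhibition and higher numbers for weaker inhibition), two compounds have been measured so far:
- compound 1 `C=C(Br)C(=O)Nc1ccc(/C=C/C(=O)c2ccccc2)cc1` at 4000 nM
- compound 2 `C=C(Br)C(=O)Nc1ccc(/C=C/C(=O)c2ccc(Cl)c(Cl)c2)cc1` at 1700 nM

Compound 2 holds the lower number of the two, and its gap to compound 1 lies beyond the scatter. Compound 3 `C=C(Br)C(=O)Nc1ccc(/C=C/C(=O)c2ccc(Br)cc2)cc1` has not yet been measured. It differs from compound 2 by 4-bromophenyl in place of 3,4-dichlorophenyl on a carbonyl carbon with 4-bromophenyl in place of 3,4-dichlorophenyl on a carbonyl carbon. Among the compounds with values here, one measured step bears on this change: a 2.4-fold lower number from compound 1 to compound 2 (0.37 log units; beyond the scatter) on replacing phenyl with 3,4-dichlorophenyl, which is modest in size. Compound 3 keeps a halogen-bearing phenyl, so only a small rise toward compound 1 is expected, with nothing beyond the scatter. The expected change is a 1.3-fold higher number from compound 2 to compound 3 (0.11 log units; within the scatter) in this assay on this estimate. Compound 3 is estimated at 2200 nM with an expected range from 1100 nM to 4200 nM in all.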

Compound 3, half-maximal inhibitory concentration: 990 nM
For compound 3 the middle estimate is 2.2-fold (0.35 log units) above the measured one, and the stated range ends above it.
By their numbers in this assay, from the lowest: compounds 3 and 2 (each within the scatter of the next); then compound 1.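

In this assay, one bromo is enough to set a compound clearly apart from compound 1: bromo in place of hydrogen on an aromatic carbon gives a 4.0-fold lower number from compound 1 to compound 3 (0.61 log units; beyond the scatter) and so shows that the two chlorines of compound 2 are not needed for a separation from the unsubstituted phenyl. Exchanging 3,4-dichlorophenyl for 4-bromophenyl on this carbonyl carbon gives a 1.7-fold lower number from compound 2 to compound 3 (0.23 log units; within the scatter) and so leaves compound 2 and compound 3 indistinguishable in this assay. No measurement at hand accounts for either step.

The compounds shown leave open whether a halogen is required at all, as a methoxy group or an amine on this phenyl is not among them. Also open, going by these compounds, is where a single chloro or fluoro on this ring would stand relative to compound 1 and compound 3.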